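Bromo to Cyano on a Benzyl Ether: Expected Cytotoxicity

The source may hold more compounds than are shown below. What is called first, only, known or untested is meant among the compounds shown, and "the series" means these compounds.

Compound 1 `O=c1c(OCc2ccccc2Br)c(-c2ccccc2)oc2cc(O)cc(O)c12` and compound 3 `O=c1c(OCc2ccc(Br)cc2)c(-c2ccccc2)oc2cc(O)cc(O)c12` share one core and differ only in 4-bromophenyl in place of 2-bromophenyl on a saturated chain carbon bound to an oxygen on an aromatic ring. In an ADME assay on Huh-5-2 cells (Homo sapiens) for cytotoxicity, read by WST assay, with a stated time of 3 days (on this read-out higher numbers stand for lower toxicity in this test and lower numbers for higher toxicity in this test), compound 1 gives 12000 nM, and compound 3 gives 2000 nM, which is a 6.0-fold lower number from compound 1 to compound 3 (0.78 log units; beyond the scatter). Compound 2 `N#Cc1ccccc1COc1c(-c2ccccc2)oc2cc(O)cc(O)c2c1=O` carries cyano in place of bromo on an aromatic carbon relative to compound 1. Compound 2 reaches only a limit of the assay in this assay, namely > 100000 nM, and this is the limit of > 100000 nM in this assay, at which 1 of the 3 values shown sits. The step is an at least 8.3-fold higher number from compound 1 to compound 2 (0.92 log units; beyond the scatter), and the comparison from compound 2 to compound 3 reads an at least 50-fold lower number from compound 2 to compound 3 (1.69 log units; beyond the scatter).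

Compound 4 `N#Cc1ccc(COc2c(-c3ccccc3)oc3cc(O)cc(O)c3c2=O)cc1` is not yet measured in this assay. It differs from compound 3 by cyano in place of bromo on an aromatic carbon. Within the data shown here, this is the same kind of change as the one from compound 1 to compound 2, but not the same: there the place was ortho to a large group, here it is para to a large group. Compound 4 is therefore expected to move by a 7.5-fold higher number from compound 3 to compound 4 (0.88 log units; beyond the scatter), an expectation that rests on compound 1 with 12000 nM and on the step of an at least 8.3-fold higher number from compound 1 to compound 2 (0.92 log units; beyond the scatter). The estimate for compound 4 in this assay is 15000 nM, with a range from 4000 nM to 100000 nM, and with a real chance that the assay again returns only a limit.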

Compound 4, half-maximal cytotoxic concentration: 48000 nM
Compound 4: the middle estimate sits 3.2-fold (0.51 log units) below what was measured; measured number inside the range.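

In this assay, cyano in place of bromo gave a 24-fold higher number from compound 3 to compound 4 (1.38 log units; beyond the scatter), so the direction of the change seen in the first pair also held in the second, and the two steps can be set side by side only with care: the same change on two cores in this assay, an at least 8.3-fold higher number (0.92 log units; beyond the scatter) from compound 1 to compound 2 and a 24-fold higher number (1.38 log units; beyond the scatter) from compound 3 to compound 4; the limit leaves it open whether they differ Compound 2 is the compound at that limit, so the earlier step has a lower bound and no exact size: the limit of > 100000 nM in this assay, at which 1 of the 4 values shown sits. The other new steps show that the place of the group also matters, with 4-cyanophenyl in place of 2-cyanophenyl giving an at least 2.0-fold lower number from compound 2 to compound 4 (0.31 log units; beyond the scatter) and 4-cyanophenyl in place of 2-bromophenyl giving a 4.0-fold higher number from compound 1 to compound 4 (0.60 log units; beyond the scatter), so the compounds support a shared direction for this change but not a fixed size that could be carried from one core to another.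

The compounds shown leave open whether other groups in place of bromo, such as a carboxylic acid or an amine, would move the number in the same direction. They also leave open whether the cyano step would hold on a longer chain in place of the benzyl link, and how large the step from compound 1 to compound 2 really is.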